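Replacing amino with hydroxy in compound 3

This account rests on a few compounds, and the source may have more. Where it says the series, first, only, none or still open, it means among the compounds named here.

In a functional assay on HT-29 cells (Homo sapiens) for antiproliferative activity, with a stated time of 72 h (a lower number here means a stronger inhibitor, a higher number a weaker inhibitor), compound 3 (`COc1ccc(-n2ccc3c(OC)c(OC)c(OC)cc32)cc1N`) stands highest of the three measured compounds at 4150 nM, against compound 1 (`COc1ccc(-n2ccc3c(OC)c(OC)c(OC)cc32)cc1`) at 179 nM and compound 2 (`COc1ccc(-n2ccc3c(OC)c(OC)c(OC)cc32)c(N)c1`) at 101 nM. Compound 4 (`COc1ccc(-n2ccc3c(OC)c(OC)c(OC)cc32)cc1O`) is unmeasured and differs from compound 3 by hydroxy in place of amino on an aromatic carbon. Two measured steps introduce amino at different carbons. The first, a 1.8-fold lower number from compound 1 to compound 2 (0.25 log units; within the scatter), bears little on this change. The second, a 23-fold higher number from compound 1 to compound 3 (1.37 log units; beyond the scatter), occurs at the carbon that changes here. Within the data shown here, no measured step involves hydroxy, so only part of that rise is expected to be undone. The expected change is an 8.3-fold lower number from compound 3 to compound 4 (0.92 log units; beyond the scatter). Compound 4 is estimated at 500 nM, within an expected range of 80 nM to 3500 nM.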

Compound 4, half-maximal inhibitory concentration: 6400 nM
The estimate for compound 4 lay 13-fold (1.11 log units) below the measured number; the measured number lies above the stated range.
By their numbers in this assay, from the lowest: compounds 2 and 1 (each within the scatter of the next); then compounds 3 and 4 (each within the scatter of the next).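

In this assay, hydroxy in place of amino gives a 1.5-fold higher number from compound 3 to compound 4 (0.19 log units; within the scatter), so at this carbon, ortho to a methoxy group, the two groups are not told apart. Hydroxy in place of hydrogen gives a 36-fold higher number from compound 1 to compound 4 (1.55 log units; beyond the scatter), so the loss seen here is not confined to amino. Nothing measured here gives a reason for this result. From the compounds shown here alone, whether a methyl group or a fluorine at this carbon would bring a similar loss stays open, as does how hydroxy would fare at the carbon bearing amino in compound 2.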